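Tertiary amide variation in a fluoroindanylidene acetamide series

The compounds below may be only part of what the source reports. "The series", "measured", "known", "first", "only" and "open" are said of these compounds alone.

Measured compounds in a functional assay on the whole organism with Mus musculus as the target, at a dose of 100 mg/kg by the intraperitoneal route; on this read-out lower numbers stand for less inhibition and higher numbers for more inhibition at the one dose given (going by the name of the read-out):
compound 1, `CCNC(=O)/C=C1\CCc2ccc(F)cc21`, gives 100%
compound 2, `CC(C)NC(=O)/C=C1\CCc2ccc(F)cc21`, gives 100%
compound 3, `O=C(/C=C1\CCc2ccc(F)cc21)N1CCCC1`, gives 33%

Compound 3 is the lowest of the three numbers. The two secondary amides, compound 1 and compound 2, share the same number, and the step of no change at the digits printed from compound 1 to compound 2 (within the scatter) lies within the scatter. The step of a number 67 percentage points lower from compound 1 to compound 3 (beyond the scatter) and the step of a number 67 percentage points lower from compound 2 to compound 3 (beyond the scatter) both mark the drop on going to the ring-closed tertiary amide.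

Compound 4, `CON(C)C(=O)/C=C1\CCc2ccc(F)cc21`, is not yet measured. It differs from compound 3 by methoxy(methyl)amino in place of pyrrolidin-1-yl on a carbonyl carbon. Both compound 3 and compound 4 therefore carry a nitrogen without hydrogen-bond donors on the carbonyl carbon; the ring is replaced by an open chain with one hydrogen-bond acceptor.

For the measured compounds named here, the steps that bear on this change are those from compound 1 and compound 2 to compound 3, both large downward. Going by the values given here, no measured pair shows a step between two tertiary amides, so the size of the step from compound 3 to compound 4 is uncertain; the expectation is a step of a number 2 percentage points higher from compound 3 to compound 4 (within the scatter) in this assay, essentially none beyond the scatter. Compound 4 is estimated at 35% in this assay, with a range from 10% to 70%.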

Compound 4, a percentage reported as inhibition, in the whole organism at one dose (the size of the read-out at that dose, not a potency): 17%
Compound 4: the middle estimate sits 18 percentage points above what was measured; the measured number falls inside the stated range.
By their numbers in this assay, from the lowest: compound 4; then compound 3; then compounds 1 and 2 (each within the scatter of the next).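

In this assay two tertiary amides can now be compared directly on the carbonyl carbon: methoxy(methyl)amino in place of pyrrolidin-1-yl gives a number 16 percentage points lower from compound 3 to compound 4 (beyond the scatter), a modest step, so the low end of this read-out is held by an open chain as well as by the ring. Set against the secondary amides, the same group gives a number 83 percentage points lower from compound 1 to compound 4 (beyond the scatter) and a number 83 percentage points lower from compound 2 to compound 4 (beyond the scatter), both large steps and well beyond the step between the tertiary amides, so among these four compounds the two with an amide hydrogen stand high and the two without it stand low, with no compound going against this. No measurement at hand gives a reason for the step between the tertiary amides or for the gap to the secondary amides.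

From the compounds shown here alone, it remains open whether other tertiary amides, such as dimethylamino or morpholin-4-yl on the carbonyl carbon, stay as low as compound 3 and compound 4. Going by these compounds, it is equally open whether the unsubstituted primary amide or a secondary amide with a longer chain or a cyclohexyl group holds the high number seen for compound 1 and compound 2.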